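The source may hold more compounds than are shown below. What is called first, only, known or untested is meant among the compounds shown, and "the series" means these compounds.

Measured compounds:
compound 1, `O/N=C/c1nc(-c2cccc3ccccc23)no1`: 8.05
compound 2, `Cc1noc(/C=N/O)n1`: 8.11

In a physicochemical assay for acid dissociation, compound 2 gives 8.11, and compound 1 gives 8.05, so the two lie within the scatter of each other and neither can be called the higher. Compound 3 is `Cc1noc(/C=N\O)n1`. Compared with compound 2, (the two compounds have the same atoms and bonds and differ only in configuration as drawn: 1 of 1 stereo elements differ; a double bond is drawn E in compound 2 and Z in compound 3). Among the measured compounds shown here, no step of this kind has been measured here, so the change from compound 2 to compound 3 is expected to be small, a number 0.09 log units higher from compound 2 to compound 3 (within the scatter), in either direction and not beyond the scatter. Compound 3 is therefore estimated at 8.2, between 7.7 and 8.7.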

Compound 3, acid dissociation constant: 8.6
Beside the measured number, compound 3's estimate is 0.40 log units below it; the measured number falls inside the stated range.
By their numbers in this assay, from the lowest: compounds 1 and 2 (each within the scatter of the next); then compound 3.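

In this assay, among the compounds shown here, this is the first step between compounds that differ in one place, and it shows that the drawn geometry of this double bond matters on its own: a number 0.49 log units higher from compound 2 to compound 3 (beyond the scatter). The earlier compounds shown here gave no such step. Since no atom or bond changes, the shift can only be traced to the change from E to Z, because of this: the fact that compounds 2 and 3 differ only in the configuration as drawn

As far as these compounds go, whether the same change gives a step of this size in compound 1 stays open. So does its effect when an amine or a carboxylic acid is carried on the shared core.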